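Acetylation of a Hydroxy Group in a Lactone Series

A few compounds are considered here, and "the series" means these few. Any claim that something is new, unique, unknown or untested is made for them only; others in the source may bear on it.

Measured in a functional assay on MCF7 cells (Homo sapiens) for cytotoxicity, read by MTT assay; on this read-out lower numbers stand for an effect already at smaller amounts and higher numbers for an effect only at larger amounts of compound:
compound 1 `C=C1C(=O)O[C@]2(C)CC[C@@H]1C[C@H](O)[C@@]1(C)CC[C@H](OC(C)=O)[C@@](C)(CCC2=O)O1` gives < 20 ug/mL.
compound 2 `C=C1C(=O)O[C@]2(C)CC[C@@H]1C[C@H](OC(C)=O)[C@@]1(C)CC[C@H](O1)[C@](C)(O)CC[C@H]2OC(C)=O` gives < 20 ug/mL.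
compound 3 `C=C1C(=O)O[C@]2(C)CC[C@@H]1C[C@H](O)[C@@]1(C)CC[C@H](O1)C(=C)CC[C@H]2OC(C)=O` gives < 20 ug/mL.

Each of these three values is a limit of this assay and not a number. Compound 3 stands at the limit of < 20 ug/mL in this assay, at which 3 of the 3 values shown sit, so no exact number is known for it. Compound 4 `C=C1C(=O)O[C@]2(C)CC[C@@H]1C[C@H](OC(C)=O)[C@@]1(C)CC[C@H](O1)C(=C)CC[C@H]2OC(C)=O` differs from compound 3 by acetyl in place of hydrogen on an oxygen on a saturated carbon. For the measured compounds named here, no step between two measured compounds is known here, so the effect of this change in this assay cannot be read from any pair. The author expects no step beyond the usual scatter. Compound 4 is expected to give about 8 ug/mL, most likely between 2 ug/mL and 20 ug/mL. That estimate means a step that the limit leaves unreadable from compound 3 to compound 4, which is expected to stay within the scatter, and the assay may again report only its limit.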

Compound 4, concentration for half-maximal effect: < 20 ug/mL
Compound 4 was reported as a limit (the forecaster's own chance of this, stated with the estimate: 70%); the middle value does not contradict the limit.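

Compound 4, like compound 3, is reported only as a limit, so no step between the two can be read: the limit of < 20 ug/mL in this assay, at which 4 of the 4 values shown sit.

The compounds shown leave open how strong each one actually is, and whether going from hydroxy to acetoxy changes the effect at all.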